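Hydroxyphenyl Hydrazone Variants on a Shared Core

This account rests on a few compounds, and the source may have more. Where it says the series, first, only, none or still open, it means among the compounds named here.

Measured compounds in a functional assay on HT-29 cells (Homo sapiens) for cytotoxicity, read by MTT assay, with a stated time of 72 h; a higher number here means a weaker inhibitor, a lower number a stronger inhibitor:

Compound 1 `CN(C)CCn1cnnc1-c1cc(Oc2ccc(NC(=O)N/N=C/c3ccc(Cl)cc3)cc2F)ccn1`: 530 nM
Compound 2 `CN(C)CCn1cnnc1-c1cc(Oc2ccc(NC(=O)N/N=C/c3ccc(O)c(F)c3)cc2F)ccn1`: 3310 nM
Compound 3 `CN(C)CCn1cnnc1-c1cc(Oc2ccc(NC(=O)N/N=C/c3cc(C(C)(C)C)cc(C(C)(C)C)c3O)cc2F)ccn1`: 680 nM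

Compound 1 gives the lowest number of the three in this assay. Compound 3 sits closest to it, and the gap between compound 1 and compound 3 lies within the scatter, so no order between them is claimed. Compound 2 stands furthest away: a 6.2-fold higher number from compound 1 to compound 2 (0.80 log units; beyond the scatter). Among the measured compounds shown here, that step, in which 3-fluoro-4-hydroxyphenyl replaces 4-chlorophenyl on the carbon with a double bond to nitrogen, is the only single-point step available and points to a weaker inhibitor.

Compound 4 `CN(C)CCn1cnnc1-c1cc(Oc2ccc(NC(=O)N/N=C/c3cc(Br)c(O)c(Br)c3)cc2F)ccn1` is not yet measured. It differs from compound 1 as follows: 3,5-dibromo-4-hydroxyphenyl in place of 4-chlorophenyl on a carbon with a double bond to nitrogen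

The step from compound 1 to compound 2 bears on this change, since both replace 4-chlorophenyl with a 4-hydroxyphenyl carrying halogen. Compound 3, also a hydroxyphenyl, stays within the scatter of compound 1, so the two hydroxyphenyl cases diverge. The expectation is therefore a modest rise, smaller than the step to compound 2: a 1.8-fold higher number from compound 1 to compound 4 (0.25 log units; within the scatter) is the expected step. Compound 4 is estimated at 950 nM, with an expected range from 400 nM to 2500 nM.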

Compound 4, half-maximal inhibitory concentration: 2670 nM
Beside the measured number, compound 4's estimate is 2.8-fold (0.45 log units) below it; the measured number lies above the stated range.
By their numbers in this assay, from the lowest: compounds 1 and 3 (each within the scatter of the next); then compounds 4 and 2 (each within the scatter of the next).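

In this assay, a 5.0-fold higher number from compound 1 to compound 4 (0.70 log units; beyond the scatter), so a second replacement of 4-chlorophenyl by a halogen-bearing hydroxyphenyl also gives a rise beyond the scatter, and the rise seen earlier is not confined to 3-fluoro-4-hydroxyphenyl. The two halogen-bearing groups are not separated here, with a 1.2-fold lower number from compound 2 to compound 4 (0.09 log units; within the scatter), even though 3,5-dibromo-4-hydroxyphenyl and 3-fluoro-4-hydroxyphenyl carry different halogens. The rise holds for these two compounds only: the hydroxyphenyl carrying two tert-butyl groups goes against any rule covering all hydroxyphenyl groups, since compound 3 gives 680 nM, within the scatter of compound 1.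

No measurement at hand accounts for the rise at this position. Open, on these data alone, is whether the rise goes with the hydroxyl, with the halogen or with the two together; a plain hydroxyphenyl, a methoxyphenyl or a dibromophenyl on the carbon with a double bond to nitrogen would separate these readings.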